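A few compounds are considered here, and "the series" means these few. Any claim that something is new, unique, unknown or untested is made for them only; others in the source may bear on it.

Working notes on three measured compounds that share one core and differ in a single aromatic substituent: compound 1 (`O=C(CCc1cccc2c1B(O)OC2)Nc1cccc(Br)c1`) with bromo, compound 2 (`O=C(CCc1cccc2c1B(O)OC2)Nc1cccc(I)c1`) with iodo and compound 3 (`CC(C)c1cccc(NC(=O)CCc2cccc3c2B(O)OC3)c1`) with isopropyl. In a functional assay on MDA-MB-231 cells (Homo sapiens) for antiproliferative activity, read by MTT assay, with a stated time of 72 h (a lower number here means a stronger inhibitor, a higher number a weaker inhibitor), compound 1 gives 720 nM, compound 2 gives 5300 nM and compound 3 gives 1600 nM. Compound 3 therefore holds the middle place of the three numbers. Its nearest neighbour is compound 1, with a 2.2-fold higher number from compound 1 to compound 3 (0.35 log units; beyond the scatter), while the gap on the other side is a 3.3-fold lower number from compound 2 to compound 3 (0.52 log units; beyond the scatter).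

The next member, compound 4 (`O=C(CCc1cccc2c1B(O)OC2)Nc1cccc(-c2ccccc2)c1`), has phenyl in place of isopropyl on an aromatic carbon. Among the measured compounds shown here, no measured compound carries phenyl, so the evidence is indirect. All three swaps measured at this carbon are modest and beyond the scatter. Both departures from bromo raised the number, with a 7.4-fold higher number from compound 1 to compound 2 (0.87 log units; beyond the scatter) alongside the smaller step to compound 3. The step from iodo to isopropyl, however, went down, so group size gives no firm direction. A modest upward move in this assay is expected, although a step within the scatter remains possible. The estimated step is a 1.8-fold higher number from compound 3 to compound 4 (0.24 log units; within the scatter). For compound 4 the estimated value is 2800 nM, with an expected range of 800 nM to 9000 nM.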

Compound 4, half-maximal inhibitory concentration: 220 nM
Compound 4: the middle estimate sits 13-fold (1.10 log units) above what was measured, and the stated range ends above it.
By their numbers in this assay, from the lowest: compound 4; then compound 1; then compound 3; then compound 2.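

In this assay, among the compounds shown here, phenyl is the first group at this aromatic carbon to give a number below that of bromo, with a 3.3-fold lower number from compound 1 to compound 4 (0.51 log units; beyond the scatter), and it also sits clearly below the other two groups, with a 7.3-fold lower number from compound 3 to compound 4 (0.86 log units; beyond the scatter) and a 24-fold lower number from compound 2 to compound 4 (1.38 log units; beyond the scatter). The earlier compounds shown here showed only rises on leaving bromo, so the series now runs in both directions from that group, and the order of the four does not follow the heavy-atom count of the group: phenyl, with more heavy atoms than isopropyl, gives the lower number. Nothing available on these compounds bears on why an aromatic ring and an isopropyl group differ so much at this carbon.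

The compounds shown leave open whether the lower number goes with the aromatic ring or with the carbon count, a question that a cyclohexyl group at the same carbon would help to separate. Also open, from the compounds shown here alone, is whether the lower number holds for a phenyl ring that itself carries a group, such as a methoxy or an amine, or for a pyridyl ring in its place.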